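This account rests on a few compounds, and the source may have more. Where it says the series, first, only, none or still open, it means among the compounds named here.

Working notes on a short series sharing one core and varied only at the amide-type nitrogen. In an assay on HEK293 cells for agonist activity at transient receptor potential cation channel subfamily M member 8 (Homo sapiens), read by fluorescence and calcium flux, with a stated time of 15 min (a higher number here means that more compound is needed for the effect, a lower number that less compound is needed), compound 1 `Cc1ccc(OCC(=O)N(CCO)Cc2cccs2)cc1` gives 900 nM, compound 2 `Cc1ccc(OCC(=O)N(Cc2cccs2)C(C)C)cc1` gives 70 nM, and compound 3 `Cc1ccc(OCC(=O)N(Cc2cccs2)c2cccnc2)cc1` gives 198 nM. Compound 3 thus stands second highest of the three numbers, with compound 2 nearest and compound 1 furthest. The measured changes at this nitrogen are a 13-fold lower number from compound 1 to compound 2 (1.11 log units; beyond the scatter) and a 4.5-fold lower number from compound 1 to compound 3 (0.66 log units; beyond the scatter), and between those two substituents is a 2.8-fold higher number from compound 2 to compound 3 (0.45 log units; beyond the scatter).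

Compound 4 `CCCN(Cc1cccs1)C(=O)COc1ccc(C)cc1` is not yet measured; it differs from compound 3 as propyl in place of pyridin-3-yl on an amide-type nitrogen. The step bearing most directly on it is a 2.8-fold higher number from compound 2 to compound 3 (0.45 log units; beyond the scatter): compound 2 carries isopropyl on the same nitrogen, and read in reverse, a chain in place of the ring points to a lower number of roughly that size. The large 13-fold lower number from compound 1 to compound 2 (1.11 log units; beyond the scatter) points the same way, in that the chain-bearing compound 2 holds the lowest number seen so far. Compound 4 is therefore expected to show a 2.2-fold lower number from compound 3 to compound 4 (0.34 log units; beyond the scatter) in this assay, a modest lowering, not a large one. The estimate for compound 4 is 90 nM, with a range of 35 nM to 250 nM.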

Compound 4, half-maximal effective concentration: 40 nM
Estimate against measurement, compound 4: 2.3-fold (0.35 log units) above, and the stated range covers the measured number.
By their numbers in this assay, from the lowest: compounds 4 and 2 (each within the scatter of the next); then compound 3; then compound 1.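

In this assay the step of a 1.8-fold lower number from compound 2 to compound 4 (0.24 log units; within the scatter) leaves propyl and isopropyl on the amide-type nitrogen without an order, so the unbranched chain serves here as well as the branched one. The change from ring to chain now has a second reading, a 5.0-fold lower number from compound 3 to compound 4 (0.69 log units; beyond the scatter) for propyl in place of pyridin-3-yl, and both compounds carrying a plain saturated chain stand apart from the ring-bearing compound 3. Among the compounds shown here, the step of a 23-fold lower number from compound 1 to compound 4 (1.35 log units; beyond the scatter) also isolates the end of the chain, since methyl in place of hydroxy on a saturated chain carbon, two bonds along the chain from an amide-type nitrogen, is the only change between the two structures and gives a large step; no measurement at hand gives a reason for any of these steps.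

Still open, going by these compounds, is whether butyl, a longer chain, or a cyclopropyl group on this nitrogen would stay near compound 4 at 40 nM in this assay or move away from it. For the compounds shown here, also open is how an amine or a carboxylic acid on the chain would read, since hydroxy is the only such group on a chain here.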